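Working notes: an indole in place of 3-fluorophenyl

The compounds below may be only part of what the source reports. "The series", "measured", "known", "first", "only" and "open" are said of these compounds alone.

Measured values in a functional assay on SK-OV-3 cells (Homo sapiens) for cytotoxicity, read by spectrophotometry, with a stated time of 72 h; a lower number here means a stronger inhibitor, a higher number a weaker inhibitor:
- compound 1 `COc1ccc(-c2cccc(=O)n2-c2cc(OC)c(OC)c(OC)c2)cc1OC`: 545 nM
- compound 2 `COc1cc(-n2c(-c3cccc(F)c3)cccc2=O)cc(OC)c1OC`: 472 nM
- compound 3 `COc1cc(-c2cccc(=O)n2-c2cc(OC)c(OC)c(OC)c2)cc(OC)c1OC`: 844 nM

The value of compound 2 lies within the scatter of those of both compound 1 and compound 3, so the three numbers do not separate. Compound 4 `COc1cc(-n2c(-c3cccc4cc[nH]c34)cccc2=O)cc(OC)c1OC` has not yet been measured. It differs from compound 2 by 1H-indol-7-yl in place of 3-fluorophenyl on an aromatic carbon.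

Among the compounds with values here, the only measured step that bears on this is a 1.5-fold higher number from compound 1 to compound 3 (0.19 log units; within the scatter). It lies within the scatter, and it is only a methoxy in place of hydrogen on an aromatic carbon, a smaller exchange than the one in view. Compound 1, compound 2 and compound 3 carry different groups at the place of the change, and their numbers stay close. None of them holds 1H-indol-7-yl, so the data offer no direct guide to the entering group. No step beyond the scatter is therefore expected in this assay, and no firm direction. The expected change is a 1.2-fold lower number from compound 2 to compound 4 (0.07 log units; within the scatter). For compound 4 the estimated value is 400 nM, with an expected range from 100 nM to 1600 nM.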

Compound 4, half-maximal inhibitory concentration: 138 nM
Compound 4: the middle estimate sits 2.9-fold (0.46 log units) above what was measured; the measured number falls inside the stated range.
By their numbers in this assay, from the lowest: compound 4; then compounds 2, 1 and 3 (each within the scatter of the next).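

In this assay the aromatic carbon next to the ring nitrogen of the shared core responds to the group it carries: 1H-indol-7-yl in place of 3-fluorophenyl gives a 3.4-fold lower number from compound 2 to compound 4 (0.53 log units; beyond the scatter). This is the first step shown that lies beyond the scatter, whereas the methoxy exchange on the aryl group gave only a 1.5-fold higher number from compound 1 to compound 3 (0.19 log units; within the scatter) and left the numbers unseparated. No measurement on hand accounts for the difference between compound 2 and compound 4, and the step itself gives only its size and direction.

The entering group differs from 3-fluorophenyl in several ways at once: it has a five-membered aromatic ring with 1 hetero atom and 1 hydrogen-bond donor, and it has no fluorine, so the compounds shown do not tell which of these features goes with the lower number. A naphthyl group at the same place, or an indole with a methyl group on its ring nitrogen, would separate the second ring from the donor hydrogen.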